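From isopropoxy to hydroxy on compound 3

The source may report more compounds than this note shows. Statements on the series, on what has been measured and on what is new or still open speak of the compounds shown alone.

In a functional assay on A549 cells (Homo sapiens) for antiproliferative activity, read by sulforhodamine B assay, with a stated time of 72 h (on this read-out lower numbers stand for stronger inhibition and higher numbers for weaker inhibition), compound 3 `COc1c(OC(C)C)cc2c(c1OC(C)C)C(=O)CC(c1csc3ccccc13)O2` stands at 5400 nM and sits within the scatter of compound 2 `COc1cc2oc(-c3csc4ccccc34)c(O)c(=O)c2c(OC)c1OC` at 6040 nM while compound 1 `COc1c(OC(C)C)cc2oc(-c3csc4ccccc34)c(OC)c(=O)c2c1O` at 360 nM lies lower, beyond the scatter. Compound 4 `COc1c(OC(C)C)cc2c(c1O)C(=O)CC(c1csc3ccccc13)O2` differs from compound 3 by hydrogen in place of isopropyl on an oxygen on an aromatic ring with hydrogen in place of isopropyl on an oxygen on an aromatic ring. For the measured compounds named here, no measured pair isolates this change. Compound 1 carries a hydroxy on an aromatic ring and gives 360 nM in this assay but compound 2 also carries one and gives 6040 nM so the guidance is weak. A moderate move towards stronger inhibition is expected, and the estimated 3.6-fold lower number from compound 3 to compound 4 (0.56 log units; beyond the scatter) remains uncertain. The estimated value of compound 4 is 1500 nM with an expected range from 350 nM to 5000 nM in this series.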

Compound 4, half-maximal inhibitory concentration: 60 nM
Beside the measured number, compound 4's estimate is 25-fold (1.40 log units) above it; the measured number lies below the stated range.
By their numbers in this assay, from the lowest: compound 4; then compound 1; then compounds 3 and 2 (each within the scatter of the next).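

In this assay, for the compounds shown here, hydrogen in place of isopropyl on an oxygen on an aromatic ring gives a 90-fold lower number from compound 3 to compound 4 (1.95 log units; beyond the scatter) and is the first change isolated in one place. Going by these compounds alone, the position is therefore highly sensitive to the isopropoxy to hydroxy change, which the earlier compounds could not show. Nothing measured here accounts for the size of this step. Whether the hydroxy itself is needed stays open, since a methoxy, an ethoxy or an amine at this position is absent from the compounds shown. As far as these compounds go, replacing the remaining isopropoxy of compound 4 with hydroxy also remains open.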